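Swapping the Furan Group for a Trimethylphenyl Ring

The compounds below may be only part of what the source reports. "The series", "measured", "known", "first", "only" and "open" are said of these compounds alone.

In an ADME assay on L02 cells (Homo sapiens) for inhibition, read by CCK-8 assay, with a stated time of 48 h (a higher number here means a weaker inhibitor of growth, a lower number a stronger inhibitor of growth), compound 1 (`Cc1ccccc1Nc1nc(Nc2ccccc2)ncc1Cl`) gives > 100000 nM, which is a limit of the assay and not a number. Compound 2 (`CN1CCN(c2ccc(Nc3ncc(Cl)c(NCc4ccccc4)n3)nc2)CC1`) gives 20300 nM. Compound 3 (`CN1CCN(c2ccc(Nc3ncc(Cl)c(NCc4ccco4)n3)nc2)CC1`) gives 45700 nM, the higher of the two true numbers. Compound 4 (`Cc1cc(C)c(Nc2nc(Nc3ccc(N4CCN(C)CC4)cn3)ncc2Cl)c(C)c1`) places 2,4,6-trimethylphenyl where compound 3 has (furan-2-yl)methyl, on a nitrogen on an aromatic ring: 2,4,6-trimethylphenyl in place of (furan-2-yl)methyl on a nitrogen on an aromatic ring. Going by the values given here, the one measured step that touches this place, a 2.3-fold higher number from compound 2 to compound 3 (0.35 log units; beyond the scatter), was modest, and it ran from a phenyl to a furan-2-yl. A similarly modest shift toward a lower number therefore seems likely, though compound 4 could also meet (the limit of > 100000 nM in this assay, at which 1 of the 3 values shown sits). The estimated change is a 1.4-fold lower number from compound 3 to compound 4 (0.15 log units; within the scatter). For compound 4, the expected value is 32000 nM, within an estimated range of 11000 nM to 90000 nM.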

Compound 4, concentration for 50% growth inhibition: 20500 nM
Beside the measured number, compound 4's estimate is 1.6-fold (0.19 log units) above it; the range from low to high includes it.
By their numbers in this assay, from the lowest: compounds 2 and 4 (each within the scatter of the next); then compound 3. At a limit, above all of these: compound 1.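

In this assay, the step of a 2.2-fold lower number from compound 3 to compound 4 (0.35 log units; beyond the scatter) shows that an aromatic ring set straight on this nitrogen, with no chain carbon in the link, is tolerated. The step of a 1.0-fold higher number from compound 2 to compound 4 (0.00 log units; within the scatter) puts the 2,4,6-trimethylphenyl and benzyl compounds level, so among these three groups only the (furan-2-yl)methyl compound stands apart. Nothing measured here accounts for either step. On these data alone, whether an open-chain group on this nitrogen, such as a cyclohexyl's acyclic counterpart hexyl or a longer chain ending in a carboxylic acid, would give a similar number remains open.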